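Methylpiperazine in place of hydroxy-methylethyl on a shared core

The source may hold more compounds than are shown below. What is called first, only, known or untested is meant among the compounds shown, and "the series" means these compounds.

Two compounds have so far been measured in an assay on HEK293 cells for agonist activity at Toll-like receptor 8 (Homo sapiens), read by spectrophotometry; a lower number here means that less compound is needed, a higher number that more compound is needed for the effect:
compound 1 `C#Cc1c(C)nc(N)nc1NCCCC` gives 4900 nM
compound 2 `CCCCNc1nc(N)nc(C)c1CCCC(C)(C)O` gives 1220 nM

Compound 2 holds the lower of the two numbers, and the gap to compound 1, which needs the higher concentration, lies beyond the usual scatter of this assay. The two compounds differ in more than one place, so the gap cannot be pinned to a single exchange.

Compound 3 `CCCCNc1nc(N)nc(C)c1CCCN1CCN(C)CC1` has not yet been measured. It differs from compound 2 in one place only: 4-methylpiperazin-1-yl in place of 1-hydroxy-1-methylethyl on a saturated chain carbon, three bonds along the chain from an aromatic carbon. Among the compounds with values here, no single-change step between measured compounds is available to calibrate an exchange of this kind, so the expectation rests on the structures alone and carries wide uncertainty. The account expects a modest move toward a lower number in this assay, with the estimated step being a 1.7-fold lower number from compound 2 to compound 3 (0.24 log units; within the scatter). For compound 3 the estimated value is 700 nM, expected to fall within a range from 150 nM to 3000 nM.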

Compound 3, half-maximal effective concentration: 179 nM
The estimate for compound 3 lay 3.9-fold (0.59 log units) above the measured number; low and high end bracket the measured number.
By their numbers in this assay, from the lowest: compound 3; then compound 2; then compound 1.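

In this assay, within the data shown here, putting 4-methylpiperazin-1-yl in place of 1-hydroxy-1-methylethyl on a saturated chain carbon, three bonds along the chain from an aromatic carbon, gives a 6.8-fold lower number from compound 2 to compound 3 (0.83 log units; beyond the scatter), and this is the first difference that can be tied to one place. It shows that this position accepts a much larger group carrying a six-membered non-aromatic ring, and that the hydrogen-bond donor of the leaving group is not needed for compound 3 to reach the lowest number of the three. Nothing at hand says which feature of the exchange accounts for the step.

On these data alone, it remains open whether the ring as a whole or its nitrogen atoms go with the lower number, a question that a morpholine, a piperidine or an open-chain dimethylamine on the same chain could separate. As far as these compounds go, it is also open whether the step would hold on a longer or shorter chain, or with a free piperazine lacking the methyl group.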